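The source may hold more compounds than are shown below. What is called first, only, known or untested is meant among the compounds shown, and "the series" means these compounds.

Working notes on the cytotoxicity series.

The parent of the step considered here is compound 1 `O=c1nc(NCc2cccc(F)c2)oc2c([N+](=O)[O-])cc(C(F)(F)F)cc12`. In an ADME assay on Vero cells (Chlorocebus sabaeus) for cytotoxicity, read by MTT assay, with a stated time of 48 h (a higher number here means a weaker inhibitor, a lower number a stronger inhibitor), compound 1 gives > 64 ug/mL, which is a limit of the assay rather than a number. Two further compounds with related cores are on hand. Compound 2 `C[C@H]1COC2(CCN(c3nc(=O)c4cc(C(F)(F)F)cc([N+](=O)[O-])c4s3)CC2)O1` in this assay gives > 64 ug/mL, again a limit of the assay and not a number. Compound 3 `CC1COC2(CCN(c3nc(=O)c4cc(C(F)(F)F)cc([N+](=O)[O-])c4o3)CC2)O1` in this assay gives 9.21 ug/mL. Among the compounds with values here, compound 1 therefore sits at the limit of > 64 ug/mL in this assay, at which 2 of the 3 values shown sit, and no measured pair in the set differs in a single place, so no measured step can be drawn on.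

The compound still to be measured is compound 4 `O=c1nc(Nc2ccccc2)oc2c([N+](=O)[O-])cc(C(F)(F)F)cc12`. It differs from compound 1 by phenyl in place of 3-fluorobenzyl on a nitrogen on an aromatic ring. The core, the nitro group and the trifluoromethyl group are unchanged.

Within the data shown here, with no single-place step measured, the expectation rests on compound 1 alone, whose value > 64 ug/mL is a limit. The step from compound 1 to compound 4 in this assay is expected to be a step that the limit leaves unreadable from compound 1 to compound 4, that is, no shift beyond the scatter, with the result most likely again reported as a limit. Compound 4 in this assay is estimated at 80 ug/mL, within 40 ug/mL to 200 ug/mL.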

Compound 4, half-maximal inhibitory concentration: 37.9 ug/mL
Beside the measured number, compound 4's estimate is 2.1-fold (0.32 log units) above it; measured number outside the range, below it.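

In this assay compound 1 gives > 64 ug/mL, which is a limit of the assay and not a number. Compound 4, with anilino in place of (3-fluorobenzyl)amino, gives a value that can be read as a number, and the change amounts to an at least 1.6-fold lower number from compound 1 to compound 4 (0.22 log units; that floor lies within the scatter), so only a floor is known for this step and its true size stays unread. What is new is that a change at this nitrogen alone, with the core, the nitro group and the trifluoromethyl group unchanged, takes the result off the limit: the limit of > 64 ug/mL in this assay, at which 2 of the 4 values shown sit.

The compounds shown do not separate the two parts of this change, since the fluorine and the carbon link of the benzyl group leave together, and the step cannot be assigned to either one. An unsubstituted benzyl group on the same nitrogen would split these two parts, while a longer chain such as phenethyl would show how the read-out follows the distance of the aromatic ring from the nitrogen.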